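Difluorophenyl swap: compound 3 to compound 4

This account rests on a few compounds, and the source may have more. Where it says the series, first, only, none or still open, it means among the compounds named here.

Measured so far in a functional assay on a cell-free system (Platelet, plasma, Homo sapiens) for inhibition; on this read-out higher numbers stand for weaker inhibition and lower numbers for stronger inhibition: compound 1 `O=C(Nc1cccc(OCc2ccc(F)cc2)c1)C1CCNCC1` gives 68000 nM; compound 2 `O=C(Nc1cccc(OCc2ccc(-c3ccccc3)cc2)c1)C1CCNCC1` gives 111000 nM; compound 3 `O=C(Nc1cccc(OCc2ccc(-c3cc(F)ccc3F)cc2)c1)C1CCNCC1` gives "not determined" (no result reported) in this assay, so no number is reported for it.

Compound 3 therefore stands nowhere on the numbers shown; its two measured relatives sit close together, with a 1.6-fold higher number from compound 1 to compound 2 (0.21 log units; within the scatter). Compound 4 `O=C(Nc1cccc(OCc2ccc(-c3cc(F)cc(F)c3)cc2)c1)C1CCNCC1` differs from compound 3 by 3,5-difluorophenyl in place of 2,5-difluorophenyl on an aromatic carbon. No measured step touches this swap: the only step shown concerns phenyl in place of fluoro and lies within the scatter. Nothing in the series suggests a move beyond the scatter in either direction, so compound 4 is expected near compounds 1 and 2. For compound 4 the estimate in this assay is 90000 nM, with a range of 30000 nM to 250000 nM.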

Compound 4, half-maximal inhibitory concentration: 27800 nM
For compound 4 the middle estimate is 3.2-fold (0.51 log units) above the measured one, and the stated range ends above it.
By their numbers in this assay, from the lowest: compound 4; then compounds 1 and 2 (each within the scatter of the next).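

In this assay, within the data shown here, the 3,5-difluorophenyl group, on an aromatic carbon para to a large group, gives a 4.0-fold lower number from compound 2 to compound 4 (0.60 log units; beyond the scatter) and also a 2.4-fold lower number from compound 1 to compound 4 (0.39 log units; beyond the scatter) as the first steps beyond the scatter. At this position, then, adding the two fluorines to the phenyl goes with a modest gain, not a loss. No measurement at hand accounts for this.

Going by these compounds, compound 3 has no number, so steps to it cannot be read and the 2,5-difluorophenyl comparison stays open. On these data alone, whether an amine or a carboxylic acid in place of the 3,5-difluorophenyl group would lower the number further also stays open.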